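The source may report more compounds than this note shows. Statements on the series, on what has been measured and on what is new or still open speak of the compounds shown alone.

Of the compounds shown here, two of the shared core have been measured. Compound 1 `COCc1cccc(CNC(=O)c2nn(-c3ccc(F)cc3)c(OC[C@@H](O)C[C@@H](O)CC(=O)O)c2C(C)C)c1` gives 31 nM in an assay on microsomes from liver for inhibition of 3-hydroxy-3-methylglutaryl-coenzyme A reductase (Rattus norvegicus); on this read-out higher numbers stand for weaker inhibition and lower numbers for stronger inhibition. Compound 2 `CC(C)c1c(C(=O)N(C)Cc2cccc(Cl)c2)nn(-c2ccc(F)cc2)c1OC[C@@H](O)C[C@@H](O)CC(=O)O` gives 8.3 nM in this assay. For the measured compounds named here, the only step between them, a 3.7-fold lower number from compound 1 to compound 2 (0.57 log units; beyond the scatter), changed the group on the amide-type nitrogen. Among the two numbers, compound 2 has the lower one, and its only neighbour, compound 1, stands a clearly higher number away.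

Compound 3 `CC(C)c1c(C(=O)N(C)[C@H](C)c2ccccc2)nn(-c2ccc(F)cc2)c1OC[C@@H](O)C[C@@H](O)CC(=O)O` has not yet been measured in this assay. It differs from compound 2 in one place: 1-phenylethyl in place of 3-chlorobenzyl on an amide-type nitrogen. Going by the values given here, the change therefore touches the same amide-type nitrogen that the step from compound 1 to compound 2 touched, and that step, a 3.7-fold lower number from compound 1 to compound 2 (0.57 log units; beyond the scatter), is the only evidence on how this position responds. It shows that groups on this nitrogen can shift the number by a modest amount, but it does not show which way a 1-phenylethyl group would move it. A small loss, within or just beyond the scatter, is expected, giving a 1.8-fold higher number from compound 2 to compound 3 (0.26 log units; within the scatter). Compound 3 is estimated at 15 nM, with a range from 4 nM to 60 nM.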

Compound 3, half-maximal inhibitory concentration: 21 nM
Beside the measured number, compound 3's estimate is 1.4-fold (0.15 log units) below it, within the range that was stated.
By their numbers in this assay, from the lowest: compound 2; then compounds 3 and 1 (each within the scatter of the next).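

Replacing 3-chlorobenzyl with 1-phenylethyl on the amide-type nitrogen gives a 2.5-fold higher number from compound 2 to compound 3 (0.40 log units; beyond the scatter) in this assay, so this position separates two groups that have the same heavy-atom count and one carbon-only aromatic ring each. Compound 3 also gives a 1.5-fold lower number from compound 1 to compound 3 (0.17 log units; within the scatter), which places it level with compound 1 even though the two differ in the whole group on that nitrogen, so quite different groups here can give numbers that cannot be told apart. Nothing measured on these compounds explains why the step from compound 2 to compound 3 has the size it does.

The step removes the chlorine and adds a branch with a defined stereocentre in a single change, so the compounds shown cannot say how much of it belongs to each. From the compounds shown here alone, a plain benzyl group on the same nitrogen, a 1-(3-chlorophenyl)ethyl group and the mirror-image form of 1-phenylethyl would each separate those parts, and how any of them would read remains open.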